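Capping a Hydroxyl: From Compound 3 to Compound 4

The source may hold more compounds than are shown below. What is called first, only, known or untested is meant among the compounds shown, and "the series" means these compounds.

Of the compounds shown here, three that share one core have been tested in an assay on isolated protein for inhibition of protein kinase C delta type (Homo sapiens), read by TR-FRET, with a stated time of 2 h; a higher number here means a weaker inhibitor, a lower number a stronger inhibitor. Compound 1 `N#Cc1cnc(NCc2cnccc2C(F)(F)F)cc1N[C@H]1C[C@@H](O)C1` carries a 3-hydroxycyclobutyl group on a nitrogen on an aromatic ring. In this assay compound 1 reaches only a limit, > 10000 nM. Compound 2 `N#Cc1cnc(NCc2cnccc2C(F)(F)F)cc1NC[C@H]1C[C@H](O)C1` carries the same ring one carbon further out, as (3-hydroxycyclobutyl)methyl. In this assay compound 2 also gives only a limit, > 10000 nM. Compound 3 `N#Cc1cnc(NCc2cnccc2C(F)(F)F)cc1NC[C@H]1CC[C@H](O)CC1` bears (4-hydroxycyclohexyl)methyl and in this assay gives 2000 nM. For the measured compounds named here, that is the only full number among the three, since the other two sit at the limit of > 10000 nM in this assay, at which 2 of the 3 values shown sit. The step from compound 1 to compound 3 is an at least 5.0-fold lower number from compound 1 to compound 3 (0.69 log units; beyond the scatter), and from compound 2 to compound 3 it is an at least 5.0-fold lower number from compound 2 to compound 3 (0.69 log units; beyond the scatter), while from compound 1 to compound 2 it is a step that the two limits leave unreadable from compound 1 to compound 2.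

Compound 4 `CO[C@H]1CC[C@H](CNc2cc(NCc3cnccc3C(F)(F)F)ncc2C#N)CC1` differs from compound 3 by methyl in place of hydrogen on an oxygen on a saturated carbon, hydroxy becoming methoxy. Going by the values given here, none of the measured steps touches the oxygen in this way, so no size of step can be read from them. For compound 4 the expected value in this assay is 3000 nM, estimated to lie between 800 nM and 12000 nM. For compound 4 that estimate means a 1.5-fold higher number from compound 3 to compound 4 (0.18 log units; within the scatter).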

Compound 4, half-maximal inhibitory concentration: > 10000 nM
Compound 4 ended at the assay's limit; the forecaster's own chance of this, stated with the estimate: 25%; middle value at least 3.3-fold (0.52 log units) from the limit.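

Until now, changes had been made only to the ring carrying the hydroxy group, whereas here the oxygen itself is altered. In this assay compound 4 gives > 10000 nM, which is a limit of the assay and not a number. Adding a single methyl to that oxygen gives an at least 5.0-fold higher number from compound 3 to compound 4 (0.69 log units; beyond the scatter), so within this small set, the one readable value is lost once the hydroxy hydrogen is replaced. The steps from compound 1 and compound 2 to compound 4 cannot be read, because each pair has two limits: the limit of > 10000 nM in this assay, at which 3 of the 4 values shown sit.

On these data alone, how much weaker compound 4 really is remains unknown. As far as these compounds go, it also remains open whether only methyl has this effect on the oxygen, or whether an ethyl ether or an acetate ester would do the same, and whether an amine could stand in for the hydroxy.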